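The compounds below may be only part of what the source reports. "The series", "measured", "known", "first", "only" and "open" are said of these compounds alone.

Of the compounds shown here, three that share one core have been measured in a functional assay on cells (Cancer cell lines, Homo sapiens) for inhibition, read by MTT assay, with a stated time of 48 h; on this read-out lower numbers stand for stronger inhibition and higher numbers for weaker inhibition. Compound 1 `O=C(/C=C/c1cccc([N+](=O)[O-])c1)NNC(=O)c1ccc2c(c1)OCCO2` gives 1560 nM, compound 2 `O=C(/C=C/c1ccccc1[N+](=O)[O-])NNC(=O)c1ccc2c(c1)OCCO2` gives 890 nM, and compound 3 `Cc1ccccc1/C=C/C(=O)NNC(=O)c1ccc2c(c1)OCCO2` gives 7710 nM. Compound 3 therefore has the highest number of the three and is the weakest inhibitor so far.

The next compound, compound 4 `COc1ccc(/C=C/C(=O)NNC(=O)c2ccc3c(c2)OCCO3)cc1`, carries 4-methoxyphenyl in place of 2-methylphenyl on a double-bonded chain carbon bound to a double-bonded chain carbon.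

All three measured steps change the group at this same place. The step between the two nitro compounds, a 1.8-fold lower number from compound 1 to compound 2 (0.24 log units; within the scatter), stays within the scatter. The two steps that bring in the 2-methylphenyl group are larger: a 4.9-fold higher number from compound 1 to compound 3 (0.69 log units; beyond the scatter) and an 8.7-fold higher number from compound 2 to compound 3 (0.94 log units; beyond the scatter). Within the data shown here, these steps show that this assay responds to changes here, but no measured compound carries a methoxy group, so none of them predicts this swap directly.

Since compound 3 at 7710 nM sits at the top of the measured range, a modest move toward lower numbers is the more likely outcome, and the expected change is a 2.2-fold lower number from compound 3 to compound 4 (0.34 log units; beyond the scatter). Compound 4 is estimated at 3500 nM, with an expected range from 1000 nM to 12000 nM.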

Compound 4, half-maximal inhibitory concentration: 930 nM
Compound 4: middle estimate off by 3.8-fold (0.58 log units), on the high side, and the stated range ends above it.
By their numbers in this assay, from the lowest: compounds 2, 4 and 1 (each within the scatter of the next); then compound 3.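

In this assay, putting 4-methoxyphenyl in place of 2-methylphenyl brings a clear move to a lower number (an 8.3-fold lower number from compound 3 to compound 4 (0.92 log units; beyond the scatter)) and leaves compound 3 as the weakest inhibitor of the four. Compound 4 lies within the scatter of both nitro compounds (a 1.0-fold higher number from compound 2 to compound 4 (0.02 log units; within the scatter); a 1.7-fold lower number from compound 1 to compound 4 (0.22 log units; within the scatter)), which shows that, among these compounds, a nitro group is not needed at this position to reach this range, and that only the 2-methylphenyl compound stands apart. Nothing measured here gives a reason for this pattern.

The step from compound 3 to compound 4 changes both the substituent and where it sits on the phenyl ring, so the compounds shown cannot tell whether the methoxy group, its location or the loss of the methyl group accounts for the difference; 4-methylphenyl and 2-methoxyphenyl compounds would help separate these possibilities. From the compounds shown here alone, it also remains open how this position would respond to quite different groups, such as an amine or a carboxylic acid on the phenyl ring.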